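Thiophen-2-yl replaces 4-nitrophenyl in compound 3

The source may report more compounds than this note shows. Statements on the series, on what has been measured and on what is new or still open speak of the compounds shown alone.

In a functional assay on NCI-H661 cells (Homo sapiens) for inhibition, read by MTT assay, with a stated time of 72 h (on this read-out higher numbers stand for weaker inhibition and lower numbers for stronger inhibition), compound 1 `Nc1ccccc1NC(=O)c1ccc(CNCc2nc(-c3cccs3)no2)cc1` gives 35800 nM. Compound 2 `O=C(NO)c1ccc(CNCc2nc(-c3ccc(Cl)cc3)no2)cc1` gives only a limit, > 100000 nM. Compound 3 `O=C(NO)c1ccc(CNCc2nc(-c3ccc([N+](=O)[O-])cc3)no2)cc1` also gives only a limit, > 100000 nM. It therefore has no exact number and stands at the limit of > 100000 nM in this assay, at which 2 of the 3 values shown sit.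

Compound 4 `O=C(NO)c1ccc(CNCc2nc(-c3cccs3)no2)cc1` has not yet been measured. It differs from compound 3 by one change, thiophen-2-yl in place of 4-nitrophenyl on an aromatic carbon.

Within the data shown here, the only measured step between close neighbours here is a step that the two limits leave unreadable from compound 2 to compound 3, so it offers no size to carry over. Compound 1 also carries thiophen-2-yl but differs elsewhere, so its 35800 nM is only a loose guide. Any readable step in this assay would be expected toward stronger inhibition, though another limit is quite possible. The estimated step is an at least 1.1-fold lower number from compound 3 to compound 4 (0.04 log units; that floor lies within the scatter), and its size is very uncertain. For compound 4 the estimate is 90000 nM, with an expected range from 20000 nM to 200000 nM.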

Compound 4, half-maximal inhibitory concentration: > 100000 nM
Compound 4: no number, only a limit (the forecaster's own chance of this, stated with the estimate: 55%); middle value at least 1.1-fold (0.04 log units) from the limit.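

In this assay, compound 4 also ends at a limit, so all three compounds with hydroxy on the amide-type nitrogen now stand there, whichever aromatic group they carry at this position: the limit of > 100000 nM in this assay, at which 3 of the 4 values shown sit. The steps among these three cannot be read, which means that thiophen-2-yl in place of 4-nitrophenyl or 4-chlorophenyl gives no effect that can be sized. Among these compounds, the one readable comparison holds thiophen-2-yl constant and changes the other end of the molecule: hydroxy in place of 2-aminophenyl gives an at least 2.7-fold higher number from compound 1 to compound 4 (0.44 log units; beyond the scatter).

The compounds shown leave open whether 2-aminophenyl on the amide-type nitrogen would also give an exact number alongside 4-chlorophenyl or 4-nitrophenyl. They also leave open whether a methyl group or a morpholine ring at this position would bring the hydroxy compounds to a readable value.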